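The source may report more compounds than this note shows. Statements on the series, on what has been measured and on what is new or still open speak of the compounds shown alone.

Working notes on the series. Compound 1 `C=CCn1ncc2cnc(COC)n2c1=O` and compound 2 `C=CCn1ncc2cncn2c1=O` share one core, while compound 3 `Oc1nncc2cncn12` is built on another; the difference between the two cores is not broken down here. In a functional assay for inhibition, with Homo sapiens as the target (a lower number here means a stronger inhibitor, a higher number a weaker inhibitor), compound 1 reaches only a limit, > 48000 nM. In this assay compound 2 likewise gives only a limit, > 48000 nM. Compound 3 also stands at a limit in this assay, > 48000 nM. Among the compounds with values here, with both ends at a limit, the step that the two limits leave unreadable from compound 2 to compound 1 cannot be sized; the only evidence on it is the limit of > 48000 nM in this assay, at which 3 of the 3 values shown sit. The change itself is methoxymethyl in place of hydrogen on an aromatic carbon. Compound 4 `COCc1ncc2cnnc(O)n12` has not yet been measured in this assay and differs from compound 3 by the same change, (methoxymethyl in place of hydrogen on an aromatic carbon), made at a place described in identical words. As the change left compound 2 and compound 1 at the same limit, no movement off the limit is foreseen for compound 4. Compound 4 is expected to sit near 70000 nM in this assay, most probably reported again as a limit, within an estimated range of 25000 nM to 250000 nM. The estimated step is a step that the limit leaves unreadable from compound 3 to compound 4.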

Compound 4, half-maximal inhibitory concentration: > 48000 nM
Compound 4 ended at the assay's limit; the forecaster's own chance of this, stated with the estimate: 85%; the middle value does not contradict the limit.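

In this assay compound 4 gives only a limit, > 48000 nM; with compound 3 also at a limit, the step between these two compounds cannot be read. The compounds shown leave open whether methoxymethyl in place of hydrogen on an aromatic carbon alters inhibition on either core, since all of them stand at one limit: the limit of > 48000 nM in this assay, at which 4 of the 4 values shown sit.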